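This account rests on a few compounds, and the source may have more. Where it says the series, first, only, none or still open, it means among the compounds named here.

Working notes on the series. The shared core of compound 1 `Nc1cc(N)c2nc(-c3ccccc3)c(Oc3ccc(Cl)c(Cl)c3)nc2c1` carries a 3,4-dichlorophenoxy group, and in a functional assay on SK-MEL-28 cells (Homo sapiens) for inhibition, read by sulforhodamine B assay, with a stated time of 48 h (on this read-out lower numbers stand for stronger inhibition of growth and higher numbers for weaker inhibition of growth), compound 1 gives 64600 nM. Among the three measured compounds this is the highest number. Compound 3 `COc1ccc(CNc2nc3cc(N)cc(N)c3nc2-c2ccccc2)cc1` gives 32400 nM in this assay, which stands within the scatter of the number for compound 1, so no order between the two can be read. Compound 2 `COc1cc(CNc2nc3cc(N)cc(N)c3nc2-c2ccccc2)cc(OC)c1OC` gives 17800 nM in this assay, a lower number than that of compound 1 by a margin beyond the scatter. Within the data shown here, both compound 2 and compound 3 replace the aryl ether of compound 1 with a benzylamino substituent, so no measured pair isolates the single change that leads to compound 4.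

Compound 4 `Nc1cc(N)c2nc(-c3ccccc3)c(Sc3ccc(F)cc3)nc2c1` differs from compound 1 in one place: (4-fluorophenyl)sulfanyl in place of 3,4-dichlorophenoxy on an aromatic carbon. The aryl ring is kept, the linking atom and the halogen pattern change. With no measured step of this kind in hand, the expectation is a step from compound 1 to compound 4 of a 1.3-fold lower number from compound 1 to compound 4 (0.11 log units; within the scatter), which is judged not beyond the scatter in either direction. For compound 4 in this assay the estimated value is 50000 nM, with a range from 15000 nM to 150000 nM.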

Compound 4, concentration for total growth inhibition: 53700 nM
The estimate for compound 4 lay 1.1-fold (0.03 log units) below the measured number; low and high end bracket the measured number.
By their numbers in this assay, from the lowest: compounds 2, 3, 4 and 1 (each within the scatter of the next, the first and the last beyond it).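

Among these compounds, at the aromatic carbon next to the ring nitrogen and ortho to a phenyl group, (4-fluorophenyl)sulfanyl in place of 3,4-dichlorophenoxy gives a 1.2-fold lower number from compound 1 to compound 4 (0.08 log units; within the scatter) in this assay, the first step that can be read at this position. This position therefore accepts a change of the linking atom and the halogen pattern together, with the aryl ring kept, without a number that can be told apart from that of compound 1, although the two changes are not separated and could differ or offset each other. No measurement on the compounds shown accounts for this result.

Open, as far as these compounds go, is how a 4-fluorophenoxy or a (3,4-dichlorophenyl)sulfanyl group on this carbon would stand against compound 1 and compound 4, since either would divide the step between the linking atom and the halogen pattern. Also open, from the compounds shown here alone, is whether a group on this carbon that carries a carboxylic acid, a piperazine or a longer alkyl chain would give a step beyond the scatter.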